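This account rests on a few compounds, and the source may have more. Where it says the series, first, only, none or still open, it means among the compounds named here.

Compound 1 `COc1cc(C)cc(-c2c(-c3ccnc(-c4ccc(C(C)=O)cc4)c3)cnn2CC#N)c1` gives 28%
Compound 2 `COc1cc(C)cc(-c2nn(CC#N)cc2-c2ccc(-c3cccc(C(C)=O)c3)nc2)c1` gives 28%
Compound 3 `Cc1cc(O)cc(-c2nn(CC#N)cc2-c2ccnc(-c3ccc(Oc4ccccc4)cc3)c2)c1` gives -12%

The three measured compounds share one core and were tested in a functional assay on SR cells (Homo sapiens) for cytotoxicity, read by sulforhodamine B assay, with a stated time of 48 h, tested at 10 uM; a lower number here means a stronger effect, a higher number a weaker effect of the compound at the concentration tested. Compound 1 stands level with compound 2 at the digits reported, the two of them together giving the highest numbers of the three; the gap between them lies within the scatter, so no order can be drawn between them. Compound 3 sits lower by a margin beyond the scatter, as its value of -12% shows against that of compound 1.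

Compound 4 `COc1cc(C)cc(-c2c(-c3ccnc(-c4ccc(N(C)C)cc4)c3)cnn2CC#N)c1` is not yet measured. It differs from compound 1 in one place: dimethylamino in place of acetyl on an aromatic carbon. For the measured compounds named here, no pair of measured compounds shows this same change, so there is no measured step to lean on. The account therefore expects a step of modest size in this assay, or none beyond the scatter, with no clear direction. On that basis compound 4 is estimated at 25%, within a range of 0% to 50%, which corresponds to an expected step of a number 3 percentage points lower from compound 1 to compound 4 (within the scatter).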

Compound 4, a percentage reported as activity, at one concentration (the size of the read-out at that concentration, not a potency): -38%
Beside the measured number, compound 4's estimate is 63 percentage points above it, outside the stated range (below it).
By their numbers in this assay, from the lowest: compound 4; then compound 3; then compounds 1 and 2 (each within the scatter of the next).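

In this assay, the position carrying the acetyl of compound 1 proves highly sensitive to what sits there: the change from 4-acetylphenyl to 4-(dimethylamino)phenyl gives a number 66 percentage points lower from compound 1 to compound 4 (beyond the scatter). This large step comes with a swap that leaves the counts of heavy atoms, hydrogen-bond donors and hydrogen-bond acceptors unchanged, and neither group brings a ring or a net charge, so those counts do not separate the two compounds. No measurement shown here accounts for the size of the step.

The compounds shown leave open whether this step is particular to dimethylamino or would also appear with a primary amine, a methoxy group or a carboxylic acid on the same carbon. They also leave open whether the same exchange would act alike on compound 2, which carries acetyl too.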